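The source may hold more compounds than are shown below. What is called first, only, known or untested is meant among the compounds shown, and "the series" means these compounds.

In a functional assay on MDA-MB-231 cells (Homo sapiens) for cytotoxicity, read by sulforhodamine B assay, tested at 10 uM (a lower number here means less inhibition, a higher number more inhibition at the concentration tested (going by the name of the read-out)), the three measured compounds gave:

Compound 1 `CCCCCc1cc(-c2cn([C@H]3C[C@H](OC(C)=O)[C@@H](COC(C)=O)O3)c(=O)[nH]c2=O)on1`: 91.5%
Compound 2 `CC(=O)OC[C@H]1O[C@@H](n2cc(-c3cc(-c4ccc(C(C)(C)C)cc4)no3)c(=O)[nH]c2=O)C[C@@H]1OC(C)=O`: 69.3%
Compound 3 `CC(=O)OC[C@H]1O[C@@H](n2cc(-c3cc(-c4ccc(C(C)C)cc4)no3)c(=O)[nH]c2=O)C[C@@H]1OC(C)=O`: 83.2%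

Compound 3 stands second of the three: on one side there is a number 8.3 percentage points lower from compound 1 to compound 3 (within the scatter), a gap within the scatter, and on the other a number 13.9 percentage points higher from compound 2 to compound 3 (beyond the scatter), a gap beyond it. Compound 4 `CCCCc1ccc(-c2cc(-c3cn([C@H]4C[C@H](OC(C)=O)[C@@H](COC(C)=O)O4)c(=O)[nH]c3=O)on2)cc1` is reached from compound 3 by the change (butyl in place of isopropyl on an aromatic carbon). Going by the values given here, two steps bear on this. Replacing pentyl by 4-isopropylphenyl gave a number 8.3 percentage points lower from compound 1 to compound 3 (within the scatter), and by 4-tert-butylphenyl gave a number 22.2 percentage points lower from compound 1 to compound 2 (beyond the scatter), so a branched group lowered the number, a less branched one less so. Butyl is unbranched, so compound 4 is expected to move upward only within the scatter, a number 3.8 percentage points higher from compound 3 to compound 4 (within the scatter). Compound 4 is estimated at 87%, between 72% and 96%.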

Compound 4, a percentage reported as inhibition, at one concentration (the size of the read-out at that concentration, not a potency): 72.2%
Compound 4: middle estimate off by 14.8 percentage points, on the high side; the measured number falls inside the stated range.
By their numbers in this assay, from the lowest: compounds 2 and 4 (each within the scatter of the next); then compounds 3 and 1 (each within the scatter of the next).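

In this assay, butyl in place of isopropyl gave a number 11 percentage points lower from compound 3 to compound 4 (beyond the scatter), so an unbranched chain at this place did not raise the number. Butyl in place of tert-butyl gave a number 2.9 percentage points higher from compound 2 to compound 4 (within the scatter), so branching alone does not order these compounds, and compound 3 goes against any such pattern. Keeping the ring and swapping only the whole side group, 4-butylphenyl in place of pentyl gave a number 19.3 percentage points lower from compound 1 to compound 4 (beyond the scatter). Nothing available gives a reason for these steps. On these data alone, how a longer chain or an amine at this place would read stays open.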